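Swapping diethylamino for methylpiperazine on the propyl chain

A few compounds are considered here, and "the series" means these few. Any claim that something is new, unique, unknown or untested is made for them only; others in the source may bear on it.

Compound 1 `O=C(N/N=C/c1cccc(Br)c1)Nc1ccc(Oc2ccnc3[nH]ccc23)c(F)c1` gives 2220 nM
Compound 2 `CCN(CC)CCCn1cccc1/C=N/NC(=O)Nc1ccc(Oc2ccnc3[nH]ccc23)c(F)c1` gives 1210 nM

In a functional assay on A549 cells (Homo sapiens) for antiproliferative activity, read by MTT assay, with a stated time of 72 h (a higher number here means a weaker inhibitor, a lower number a stronger inhibitor), compound 2 gives 1210 nM and compound 1 gives 2220 nM (a gap within the usual scatter of repeated measurements). Compound 2 therefore stands level with compound 1 on these two numbers, and neither can be set ahead of the other.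

Compound 3 `CN1CCN(CCCn2cccc2/C=N/NC(=O)Nc2ccc(Oc3ccnc4[nH]ccc34)c(F)c2)CC1` has not yet been measured. It differs from compound 2 in one place (4-methylpiperazin-1-yl in place of diethylamino on a saturated chain carbon, three bonds along the chain from an aromatic nitrogen) with 4-methylpiperazin-1-yl in place of diethylamino on a saturated chain carbon, three bonds along the chain from an aromatic nitrogen.

Among the compounds with values here, no two measured compounds differ in only one place, so the data hold no measured step for this or any other single change. For this assay the expectation is therefore no step beyond the scatter, in neither direction, taking compound 2 at 1210 nM as the starting point. The expected change a 1.1-fold lower number from compound 2 to compound 3 (0.04 log units; within the scatter) is small. Compound 3 is expected at 1100 nM (estimated range 450 nM to 2700 nM).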

Compound 3, half-maximal inhibitory concentration: 2200 nM
Estimate against measurement, compound 3: 2.0-fold (0.30 log units) below, within the range that was stated.
By their numbers in this assay, from the lowest: compounds 2, 3 and 1 (each within the scatter of the next).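

In this assay, the exchange of diethylamino for 4-methylpiperazin-1-yl provides the first measured single change among these compounds (a 1.8-fold higher number from compound 2 to compound 3 (0.26 log units; within the scatter)). At this saturated chain carbon, three bonds along the chain from an aromatic nitrogen, a group with no ring and one carrying a six-membered non-aromatic ring with 2 hetero atoms therefore cannot be told apart on this read-out, so this one change gives no sign that the choice between these two groups matters for the antiproliferative reading. The data offer no measurement that could explain this outcome.

The compounds shown leave open whether the reading would stay level with other groups at the same place, such as morpholine, pyrrolidine, piperazine without its methyl group, or a carboxylic acid at the end of the chain. They also leave open how the reading depends on the propyl chain itself, since a shorter ethyl chain or a longer butyl chain carrying the same 4-methylpiperazin-1-yl group does not appear among them.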